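The compounds below may be only part of what the source reports. "The series", "measured", "known", "first", "only" and "open" are said of these compounds alone.

Measured so far:
compound 1 `CCOc1ccc(O)c(C(=O)/C=C/c2ccc(C)s2)c1` — 43400 nM
compound 2 `Cc1ccc(/C=C/C(=O)c2cc(OC(C)C)ccc2O)s1` — 30200 nM
compound 3 `CCOc1ccc(OC)cc1C(=O)/C=C/c1ccc(C)s1` — 100 nM

In a functional assay on HT-29 cells (Homo sapiens) for cytotoxicity, read by MTT assay (on this read-out higher numbers stand for weaker inhibition and lower numbers for stronger inhibition), the three numbers span a wide range. Compound 1 and compound 2 share a core; the change between them is methyl in place of hydrogen on a saturated chain carbon bound to an oxygen on an aromatic ring and a saturated chain carbon and it gave a 1.4-fold lower number from compound 1 to compound 2 (0.16 log units; within the scatter). Compound 3 sits on another core; the difference between the core of compound 3 and that of compound 1 is not broken down here. Its number is the lowest of the three, beyond the scatter from both others.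

Compound 4 `CCCOc1ccc(OC)cc1C(=O)/C=C/c1ccc(C)s1` is to be measured. It differs from compound 3 by methyl in place of hydrogen on a saturated chain carbon, two bonds along the chain from an oxygen on an aromatic ring. This is the same kind of change as that from compound 1 to compound 2, not the same: there the methyl entered on a saturated chain carbon bound to an oxygen on an aromatic ring and a saturated chain carbon, here on a saturated chain carbon, two bonds along the chain from an oxygen on an aromatic ring. Because the earlier step of a 1.4-fold lower number from compound 1 to compound 2 (0.16 log units; within the scatter) stayed within the scatter, a step of similar size is expected here, a 1.1-fold lower number from compound 3 to compound 4 (0.05 log units; within the scatter). For compound 4 in this assay the estimate is 90 nM, expected to fall between 35 nM and 250 nM.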

Compound 4, half-maximal inhibitory concentration: 86600 nM
Beside the measured number, compound 4's estimate is 960-fold (2.98 log units) below it, and the stated range ends below it.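

In this assay the added methyl gave an 870-fold higher number from compound 3 to compound 4 (2.94 log units; beyond the scatter), so ethoxy to propoxy on the core of compound 3 is a large step toward weaker inhibition. The outcome of this change does not carry over from the core of compound 1: the same change on two cores in this assay, a 1.4-fold lower number (0.16 log units; within the scatter) from compound 1 to compound 2 and an 870-fold higher number (2.94 log units; beyond the scatter) from compound 3 to compound 4, 1200-fold (3.10 log units) apart, beyond the scatter of two such steps. This does not separate the core from the place of the methyl, which entered on a different chain carbon in each pair, and one pair per core gives no rule for the series.

Open, on these data alone, is what the core of compound 3 does with a methyl on the saturated chain carbon bound to the oxygen. Also open, as far as these compounds go, is whether a longer chain such as butoxy, or an amine on the chain, behaves like propoxy there.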